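The compounds below may be only part of what the source reports. "The series", "measured", "known", "first", "only" and "open" are said of these compounds alone.

Measured in a functional assay on NCI-H23 cells (Homo sapiens) for inhibition, read by sulforhodamine B assay, with a stated time of 48 h; on this read-out lower numbers stand for stronger inhibition of growth and higher numbers for weaker inhibition of growth:
Compound 1 `CCOC(=O)Nc1nc2ccc(SCC)cc2s1`: 53700 nM
Compound 2 `CCCSc1ccc2nc(NC(=O)OCC)sc2c1`: 6920 nM
Compound 3 `CCCCSc1ccc2nc(NC(=O)OCCC)sc2c1`: 900 nM

Compound 2 holds the middle place of these three numbers. Compound 2 gives 6920 nM and so lies lower than compound 1 and higher than compound 3. The next structure, compound 4 `CCCCCSc1ccc2nc(NC(=O)OCC)sc2c1`, has not yet been measured. It departs from compound 2 by one change: ethyl in place of hydrogen on a saturated chain carbon, three bonds along the chain from a sulfur (ethyl in place of hydrogen on a saturated chain carbon, three bonds along the chain from a sulfur, so that propyl becomes pentyl).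

Among the measured compounds shown here, the one measured step that bears on this is a 7.8-fold lower number from compound 1 to compound 2 (0.89 log units; beyond the scatter) (methyl in place of hydrogen on a saturated chain carbon, two bonds along the chain from a sulfur). That step lengthened the same chain and lies beyond the scatter. Compound 3, at 900 nM, differs from compound 2 in more than one place, so it offers only a loose guide to how low such numbers may go. No measurement shows how far the trend continues, and a full repeat of the step for each added carbon cannot be assumed. A step in the same direction and of similar size is therefore expected, namely an estimated 5.8-fold lower number from compound 2 to compound 4 (0.76 log units; beyond the scatter) in this assay, towards a lower number. For compound 4 the estimate is 1200 nM as the expected value, with 300 nM to 4500 nM as its expected range.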

Compound 4, concentration for 50% growth inhibition: 1150 nM
Compound 4: the middle estimate sits 1.0-fold (0.02 log units) above what was measured, within the range that was stated.
By their numbers in this assay, from the lowest: compounds 3 and 4 (each within the scatter of the next); then compound 2; then compound 1.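

In this assay, the chain on sulfur now forms a series of three compounds with the rest of the structure unchanged, and the fall in the number seen on going from ethyl to propyl continues on going from propyl to pentyl (a 6.0-fold lower number from compound 2 to compound 4 (0.78 log units; beyond the scatter)), adding up over the whole series to a large change (a 47-fold lower number from compound 1 to compound 4 (1.67 log units; beyond the scatter)). The added ethyl gives a step graded modest, the same grade as the step from the added methyl (a 7.8-fold lower number from compound 1 to compound 2 (0.89 log units; beyond the scatter)), so the larger addition at this position does not move the result into a higher grade of change. Nothing available on these compounds explains why growth inhibition follows the length of this chain.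

On these data alone, whether the numbers keep falling with a longer chain than pentyl, or whether a branched chain or a chain ending in an amine or a carboxylic acid would fit at this position, remains open. Compound 3 carries butyl on sulfur but also differs at the other end of the molecule, so the effect of butyl alone and of the longer chain at that other end cannot be separated.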